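Carbamoyl in place of pyridin-4-yl on a weak scaffold

The source may hold more compounds than are shown below. What is called first, only, known or untested is meant among the compounds shown, and "the series" means these compounds.

Measured compounds, in a functional assay on PC-3 cells (Homo sapiens) for inhibition, read by sulforhodamine B assay, with a stated time of 48 h; on this read-out lower numbers stand for stronger inhibition and higher numbers for weaker inhibition:
Compound 1, `O=c1c([C@@H]2C[C@H](c3ccccc3)ON2c2ccccc2)coc2ccccc12`, gives only a limit, > 60000 nM.
Compound 2, `O=c1c([C@@H]2C[C@H](c3ccncc3)ON2c2ccccc2)coc2ccccc12`, gives 46000 nM.

Going by the values given here, compound 2 holds the only real number so far; the other value is the limit of > 60000 nM in this assay, at which 1 of the 2 values shown sits. Among the compounds with values here, the one measured step, an at least 1.3-fold lower number from compound 1 to compound 2 (0.11 log units; that floor lies within the scatter), is too small to stand out from the scatter, so it gives no direction to build on.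

Compound 3, `NC(=O)[C@H]1C[C@@H](c2coc3ccccc3c2=O)N(c2ccccc2)O1`, differs from compound 2 by carbamoyl in place of pyridin-4-yl on a saturated ring carbon. Within the data shown here, no measured step swaps an aromatic ring for a small amide at this position, so the expectation rests on compound 2 alone and on the near-flat step already seen. The step from compound 2 to compound 3 is expected to be small, a 1.1-fold higher number from compound 2 to compound 3 (0.04 log units; within the scatter), with a real chance that only a limit is reported. Compound 3 is therefore estimated at 50000 nM, between 15000 nM and 160000 nM.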

Compound 3, half-maximal inhibitory concentration: > 60000 nM
Compound 3: only a limit was reported; the forecaster's own chance of this, stated with the estimate: 45%; middle value at least 1.2-fold (0.07 log units) from the limit.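

Replacing the aromatic pyridin-4-yl with carbamoyl, a group with no ring and with a hydrogen-bond donor, on this saturated ring carbon next to the ring oxygen gives an at least 1.3-fold higher number from compound 2 to compound 3 (0.11 log units; that floor lies within the scatter). Going by these compounds alone, this change therefore brings no gain that can be seen in this assay, and the only readable step is too small to show that it costs anything either. The step between the phenyl of compound 1 and the carbamoyl of compound 3 cannot be read, and with phenyl, pyridin-4-yl and carbamoyl tried at this position, the results crowd at one end of the scale: the limit of > 60000 nM in this assay, at which 2 of the 3 values shown sit.

How far compound 3 really lies from compound 2 remains hidden, since only a limit is reported for compound 3. On these data alone, it also remains open whether an amine, a carboxylic acid or a longer chain on this carbon would give a clearly lower number.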